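The source may hold more compounds than are shown below. What is called first, only, known or untested is meant among the compounds shown, and "the series" means these compounds.

Compound 2 `CN1[C@@H]2c3[nH]c4ccccc4c3C[C@H]1[C@H](C#N)N1[C@@H](CNC(=O)c3ccc(F)cc3)c3[nH]c4ccccc4c3C[C@@H]21`: 140 nM. Compound 1 `CN1[C@@H]2c3[nH]c4ccccc4c3C[C@H]1[C@H](C#N)N1[C@@H](CNC(=O)c3cccc(C(F)(F)F)c3)c3[nH]c4ccccc4c3C[C@@H]21`: 630 nM. Compound 3 `CN1[C@@H]2c3[nH]c4ccccc4c3C[C@H]1[C@H](C#N)N1[C@@H](CNC(=O)c3cc4ccccc4[nH]3)c3[nH]c4ccccc4c3C[C@@H]21`: 880 nM.

All three share one core and differ only in the group on the amide carbonyl carbon. In a functional assay on HCT-116 cells (Homo sapiens) for cytotoxicity, read by MTT assay, with a stated time of 72 h (on this read-out lower numbers stand for stronger inhibition and higher numbers for weaker inhibition), compound 2 gives the lowest of the three numbers; compound 1 stands nearest, with a 4.5-fold lower number from compound 1 to compound 2 (0.65 log units; beyond the scatter), and compound 3 furthest, with a 6.3-fold higher number from compound 2 to compound 3 (0.80 log units; beyond the scatter). Compound 4 `CN1[C@@H]2c3[nH]c4ccccc4c3C[C@H]1[C@H](C#N)N1[C@@H](CNC(=O)/C=C/c3cccc(C(F)(F)F)c3)c3[nH]c4ccccc4c3C[C@@H]21` is not yet measured; it carries 2-(3-(trifluoromethyl)phenyl)ethenyl in place of 4-fluorophenyl on a carbonyl carbon. Among the compounds with values here, the step from compound 1 to compound 2 bears on this, since compound 1 already holds the 3-(trifluoromethyl)phenyl and gives the higher number; the ethenyl link itself is covered by no measured step. Compound 4 is therefore expected to give a higher number than compound 2, a step of about a 3.6-fold higher number from compound 2 to compound 4 (0.55 log units; beyond the scatter). The estimate for compound 4 is 500 nM, with a range from 150 nM to 1600 nM.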

Compound 4, half-maximal inhibitory concentration: 610 nM
Estimate against measurement, compound 4: 1.2-fold (0.09 log units) below, and the stated range covers the measured number.
By their numbers in this assay, from the lowest: compound 2; then compounds 4, 1 and 3 (each within the scatter of the next).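

The ethenyl link is new here, and in this assay compound 4, which carries it on the 3-(trifluoromethyl)phenyl, stays within the scatter of compound 1 (a 1.0-fold lower number from compound 1 to compound 4 (0.01 log units; within the scatter)). Compound 4 also stays within the scatter of compound 3 (a 1.4-fold lower number from compound 3 to compound 4 (0.16 log units; within the scatter)), but not of compound 2 (a 4.4-fold higher number from compound 2 to compound 4 (0.64 log units; beyond the scatter)). Among these four amides, only compound 2, with its 4-fluorophenyl, stands apart from all the others.

From the compounds shown here alone, whether 2-(4-fluorophenyl)ethenyl or an aminomethyl group on the carbonyl carbon would match compound 2 remains open. Nothing shown here explains why these numbers differ.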